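Inversion at the chain stereocentre in a tetrazole series

A few compounds are considered here, and "the series" means these few. Any claim that something is new, unique, unknown or untested is made for them only; others in the source may bear on it.

Within the data shown here, compound 1 `CC(C)(N)C(=O)N[C@H](COCc1ccccc1)c1nnnn1[C@H](CC#N)COc1ccccc1` is the only member here with a single number: in a functional assay on H4 cells for agonist activity at growth hormone secretagogue receptor type 1 (Homo sapiens) (a higher number here means a weaker inhibitor, a lower number a stronger inhibitor), compound 1 gives 7.5 nM. Compound 2 `CC(C)(N)C(=O)N[C@H](COCc1ccccc1)c1nnnn1C(/C=C/c1ccccc1)CC#N` returns two entries, 737 nM; 12 nM (2 entries), and compound 3 `CC(C)(N)C(=O)N[C@H](COCc1ccccc1)c1nnnn1C(CC#N)COc1ccccc1F` likewise two, 696 nM; 18 nM (2 entries); the spread inside each pair, the several entries of compound 2 in this assay, 737 nM; 12 nM (2 entries) and (the several entries of compound 3 in this assay, 696 nM; 18 nM (2 entries)), is far wider than the usual scatter, so the footing of the series is uncertain. Compound 4 `CC(C)(N)C(=O)N[C@H](COCc1ccccc1)c1nnnn1[C@@H](CC#N)COc1ccccc1` keeps every atom and bond of compound 1 and differs only as follows: the two compounds have the same atoms and bonds and differ only in configuration as drawn: 1 of 2 stereo elements differ; a stereocentre at a saturated chain carbon is drawn R in compound 1 and S in compound 4. Among the measured compounds shown here, no measured pair tells how this stereocentre matters. Compound 4 is expected at 40 nM, plausibly between 5 nM and 400 nM. The step from compound 1 to compound 4 is estimated as a 5.3-fold higher number from compound 1 to compound 4 (0.73 log units; beyond the scatter), a loss beyond the scatter.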

Compound 4, inhibition constant: 197 nM
For compound 4 the middle estimate is 4.9-fold (0.69 log units) below the measured one; the range from low to high includes it.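

This stereocentre at a saturated chain carbon matters in this assay: going from R to S costs a large loss of potency (a 26-fold higher number from compound 1 to compound 4 (1.42 log units; beyond the scatter)). The step can be assigned to configuration alone, because nothing else separates the pair: the fact that compounds 1 and 4 differ only in the configuration as drawn

On these data alone, whether R stays preferred when a carboxylic acid or a longer chain replaces the nitrile remains open. Compounds 2 and 3 are drawn without configuration at this carbon, so their entries cannot be assigned to either form, and the spread is wide for compound 2 as for compound 3: the several entries of compound 2 in this assay, 737 nM; 12 nM (2 entries)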